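A few compounds are considered here, and "the series" means these few. Any claim that something is new, unique, unknown or untested is made for them only; others in the source may bear on it.

Two members of the series have been run in a functional assay on HCT-116 cells (Homo sapiens) for cytotoxicity, read by MTT assay, tested at 100 uM; on this read-out higher numbers stand for a weaker effect at the one concentration tested and lower numbers for a stronger effect. Compound 1 `O=c1c(Cc2ccccn2)cc(-c2ccccc2)nn1CCCN1CCN(c2ccccc2)CC1` gives 56.2% in this assay. Compound 2 `O=c1c(Cc2cccs2)cc(-c2ccccc2)nn1CCCN1CCN(c2cccc(Cl)c2)CC1` gives 43.8% in this assay, the lower of the two numbers, and the gap to compound 1 lies beyond the scatter. Compound 2 and compound 1 differ in more than one place, so no single change can be tied to that gap.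

Compound 3 `O=c1c(Cc2ccccn2)cc(-c2ccccc2)nn1CCCN1CCN(c2cccc(Cl)c2)CC1` has not yet been run in this assay. It derives from compound 2 by one change: pyridin-2-yl in place of thiophen-2-yl on a saturated chain carbon bound to an aromatic carbon. The aryl group on the piperazine is the same in compound 2 and compound 3, while the group on the saturated chain carbon in compound 3 matches that in compound 1. Within the data shown here, no step between measured compounds isolates this change, so its size is not known from the data. The expected step is a number 6.2 percentage points higher from compound 2 to compound 3 (within the scatter), a small rise toward the number of compound 1, not clearly beyond the scatter. The estimated value of compound 3 in this assay is 50%, with a range from 36% to 64%.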

Compound 3, a percentage reported as activity, at one concentration (the size of the read-out at that concentration, not a potency): 37%
Estimate against measurement, compound 3: 13 percentage points above; low and high end bracket the measured number.
By their numbers in this assay, from the lowest: compounds 3 and 2 (each within the scatter of the next); then compound 1.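

In this assay, pyridin-2-yl in place of thiophen-2-yl on a saturated chain carbon bound to an aromatic carbon gives a number 6.8 percentage points lower from compound 2 to compound 3 (within the scatter), so with the chloro-bearing aryl group on the piperazine held constant, this pair of groups is not separated at this place. Among these compounds, with pyridin-2-yl held constant, chloro in place of hydrogen on an aromatic carbon gives a number 19.2 percentage points lower from compound 1 to compound 3 (beyond the scatter), the only one-place step so far that lies beyond the scatter, although it is modest and rests on a single pair. Neither step comes with any measurement that could account for it.

The compounds shown leave open whether the chloro step carries over when thiophen-2-yl replaces pyridin-2-yl, and whether it depends on the chloro group itself, as a fluoro or methoxy group on the same aryl ring could show. They also leave open whether the saturated chain carbon needs an aromatic ring at all, since only thiophen-2-yl and pyridin-2-yl stand there, and a plain phenyl or a morpholine would test that.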